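The source may report more compounds than this note shows. Statements on the series, on what has been measured and on what is new or still open speak of the compounds shown alone.

Measured compounds:
- compound 1, `CC(C)[C@@H](NC(=O)/C=C/c1ccncc1-c1ccc2ccccc2c1)C(=O)O`: "not determined" (no result reported)
- compound 2, `Cn1ncc2cc(-c3cnccc3/C=C/C(=O)N3CCOCC3)ccc21`: 356 nM
- compound 3, `CN1CCN(c2ccc(Nc3cnccc3/C=C/C(N)=O)cc2)CC1`: "not determined" (no result reported)

The shared theme of this set is an acrylamide attached to a pyridine ring that also carries an aromatic partner. Only compound 2 has a number in an assay on a protein complex for inhibition of CDK8/Cyclin C (Homo sapiens), with a stated time of 1 h; a lower number here means a stronger inhibitor, a higher number a weaker inhibitor: compound 2 gives 356 nM. Compound 1 stands without a single number in this assay, and compound 3 is a further entry without one, so nothing can be said about where compound 1 sits relative to compound 2 on the numbers shown.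

The new compound 4, `O=C(O)CCNC(=O)/C=C/c1ccncc1-c1ccc2ccccc2c1`, keeps the core of compound 1 and changes only the group on the amide-type nitrogen: 2-carboxyethyl in place of 1-carboxy-2-methylpropyl on an amide-type nitrogen. The group that leaves carries a branched chain and a defined stereocentre; the group that enters is a shorter, unbranched chain with the same carboxylic acid end. For the measured compounds named here, since compound 1 has no number in this assay, no step from compound 1 to compound 4 can be given, and no pattern can be drawn from the two other compounds, which differ from compound 4 in more than one place.

The expectation for compound 4 can therefore rest only loosely on compound 2 and its value 356 nM as an anchor for the series. Compound 4 is estimated to give 300 nM in this assay, with a plausible range from 60 nM to 1500 nM.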

Compound 4, half-maximal inhibitory concentration: 870 nM
Beside the measured number, compound 4's estimate is 2.9-fold (0.46 log units) below it; measured number inside the range.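

For the compounds shown here, compound 1 has no single number in this assay and compound 4 gives 870 nM there, so no step between them can be read. The compounds shown leave open how exchanging 1-carboxy-2-methylpropyl for 2-carboxyethyl on the amide-type nitrogen changes inhibition in this assay here. No evidence shown bears on the value of compound 4.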